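Methylsulfanyl for dimethylamino: working notes on the series

The compounds below may be only part of what the source reports. "The series", "measured", "known", "first", "only" and "open" are said of these compounds alone.

Measured in a functional assay on L1210 cells (Mus musculus) for inhibition; on this read-out higher numbers stand for weaker inhibition and lower numbers for stronger inhibition:
- compound 1 `C=C1[C@@H](O)[C@H](n2cnc3c(Cl)nc(N)nc32)O[C@@H]1CO` gives 441000 nM
- compound 2 `C=C1[C@H](n2cnc3c(N)nc(N)nc32)O[C@H](CO)[C@H]1O` gives 8200 nM
- compound 3 `C=C1[C@H](n2cnc3c(N(C)C)nc(N)nc32)O[C@H](CO)[C@H]1O` gives 454000 nM

Compound 3 lies within the scatter of compound 1 at the top of these numbers, and far from compound 2. Compound 4 `C=C1[C@H](n2cnc3c(SC)nc(N)nc32)O[C@H](CO)[C@H]1O` carries methylsulfanyl in place of dimethylamino on an aromatic carbon and awaits measurement. Going by the values given here, the one measured step at this place is large, a 55-fold higher number from compound 2 to compound 3 (1.74 log units; beyond the scatter), and it introduced the dimethylamino group that compound 4 lacks. Among the compounds with values here, no measured step covers methylsulfanyl, so the expectation is loose: a move back towards compound 2, smaller than that step. The expected change is a 7.6-fold lower number from compound 3 to compound 4 (0.88 log units; beyond the scatter) in this assay, beyond the scatter. For compound 4 the estimated value is 60000 nM within an expected range of 10000 nM to 400000 nM.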

Compound 4, half-maximal inhibitory concentration: > 500000 nM
Compound 4: only a limit was reported; the forecaster's own chance of this, stated with the estimate: 10%; middle value at least 8.3-fold (0.92 log units) from the limit.
By their numbers in this assay, from the lowest: compound 2; then compounds 1 and 3 (each within the scatter of the next). At a limit, above all of these: compound 4.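

In this assay compound 4 is reported only as a limit, > 500000 nM. Methylsulfanyl brings no move back towards the amino compound, and it is the second group after dimethylamino to give a large step away from amino at this position: an at least 60-fold higher number from compound 2 to compound 4 (1.78 log units; beyond the scatter). The remaining step leaves methylsulfanyl and dimethylamino unordered: an at least 1.1-fold higher number from compound 3 to compound 4 (0.04 log units; that floor lies within the scatter).

Open, as far as these compounds go, is whether a methylamino or hydroxyl group on this aromatic carbon would stay close to compound 2 or fall with compound 3 and compound 4. The true size of both new steps also stays open, as only a floor can be read: the limit of > 500000 nM in this assay, at which 1 of the 4 values shown sits.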